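Swapping Propyl for Cyclopentyl in a Level Series

The source may hold more compounds than are shown below. What is called first, only, known or untested is meant among the compounds shown, and "the series" means these compounds.

In a physicochemical assay for solubility, at pH 1.1 (on this read-out higher numbers stand for higher solubility and lower numbers for lower solubility), compound 1 (`CCCN(Cc1ccc(OCCN2C(=O)CCC2=O)c(C)c1)C(CC(=O)O)c1ccc(Cl)cc1`) gives 3000000 nM and compound 2 (`CCN(Cc1ccc(OCCN2C(=O)CCC2=O)c(C)c1)C(CC(=O)O)c1ccc(Cl)cc1`) gives 3000000 nM while compound 3 (`CCCCN(Cc1ccc(OCCN2C(=O)CCC2=O)c(C)c1)C(CC(=O)O)c1ccc(Cl)cc1`) gives 3000000 nM so compound 3 stands level with both of the others. The next structure is compound 4 (`Cc1cc(CN(CC2CCCC2)C(CC(=O)O)c2ccc(Cl)cc2)ccc1OCCN1C(=O)CCC1=O`), which carries cyclopentyl in place of propyl on a saturated chain carbon bound to an amine nitrogen. The measured steps that bear on this swap all alter the same chain. They read no change at the digits printed from compound 1 to compound 2 (within the scatter) then no change at the digits printed from compound 1 to compound 3 (within the scatter) and finally no change at the digits printed from compound 2 to compound 3 (within the scatter) so none of them reaches beyond the scatter. Within the data shown here, no measured compound carries a ring in this place, which makes these steps only a loose guide. Resting on them, the expected result is no change at the digits printed from compound 3 to compound 4 (within the scatter) in this assay with no shift in either direction beyond the scatter. For compound 4 the estimated value is 3000000 nM within an expected range of 1500000 nM to 3500000 nM for now.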

Compound 4, solubility: 3000000 nM
Beside the measured number, compound 4's estimate shows no gap at the digits printed; measured number inside the range.
By their numbers in this assay, from the lowest: compounds 1, 2, 3 and 4 (each within the scatter of the next).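

With a ring now at this place, on a saturated chain carbon bound to an amine nitrogen, this assay shows no change at the digits printed from compound 3 to compound 4 (within the scatter) for the swap of propyl for cyclopentyl. Among these compounds, the wider comparisons agree, with no change at the digits printed from compound 2 to compound 4 (within the scatter) and also no change at the digits printed from compound 1 to compound 4 (within the scatter) among the steps read here, so the level reading, until now seen only with open chains, also holds for one five-membered non-aromatic ring of carbon only. Nothing available explains this level reading.

From the compounds shown here alone, whether the same reading would hold for a phenyl ring, or for a chain ending in an amine or a hydroxyl group at this place, remains open. The compounds shown also leave open how these four would compare on any other read-out.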